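Swapping the Piperazine Amide for a Phenylpropylamide

The source may hold more compounds than are shown below. What is called first, only, known or untested is meant among the compounds shown, and "the series" means these compounds.

Measured compounds:
compound 1 `CCCSc1nc(Cl)c2c(n1)N(Cc1ccccc1)C(C(=O)N1CCN(C(=O)OC(C)(C)C)CC1)N2`, 29000 nM
compound 2 `CCCSc1nc(Cl)c2c(n1)N(Cc1ccccc1)C(C(=O)N1CCN(C)CC1)N2`, 2800 nM
compound 3 `CCCSc1nc(Cl)c2c(n1)N(Cc1ccco1)C(C(=O)N1CCN(C)CC1)N2`, 13600 nM

In a functional assay on A549 cells (Homo sapiens) for antiproliferative activity, read by MTT assay, with a stated time of 72 h (on this read-out higher numbers stand for weaker inhibition and lower numbers for stronger inhibition), compound 2 stands lowest of the three numbers. Its nearest neighbour is compound 3, reached by the step of a 4.9-fold higher number from compound 2 to compound 3 (0.69 log units; beyond the scatter); the furthest is compound 1, which sits above it by the step of a 10-fold lower number from compound 1 to compound 2 (1.02 log units; beyond the scatter).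

Compound 4 `CCCSc1nc(Cl)c2c(n1)N(Cc1ccccc1)C(C(=O)NCCCc1ccccc1)N2` differs from compound 2 in a single place: (3-phenylpropyl)amino in place of 4-methylpiperazin-1-yl on a carbonyl carbon. Going by the values given here, of the two measured steps, the one from compound 1 to compound 2 is the one that bears on this change, since it also alters the group carried on that carbonyl carbon, and it was large. The step from compound 2 to compound 3 touches a different part of the shared core and speaks only to how readily the number moves away from compound 2. Both show that this series responds strongly to single changes, so a step beyond the scatter is expected in this assay. Among the compounds with values here, because compound 2 is the lowest at 2800 nM and the present change is more extensive than the one from compound 1 to compound 2, a rise in the number is expected for compound 4, estimated as a 2.9-fold higher number from compound 2 to compound 4 (0.46 log units; beyond the scatter). Compound 4 is therefore expected to give about 8000 nM, within 2000 nM to 40000 nM.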

Compound 4, half-maximal inhibitory concentration: 9430 nM
Compound 4: middle estimate off by 1.2-fold (0.07 log units), on the low side; low and high end bracket the measured number.
By their numbers in this assay, from the lowest: compound 2; then compounds 4 and 3 (each within the scatter of the next); then compound 1.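

Set against the earlier compounds, which kept the piperazine ring and changed only the group on its far nitrogen or a group elsewhere on the shared core, compound 4 is the first to lose the 4-methylpiperazin-1-yl group from the carbonyl carbon altogether, and in this assay the exchange for (3-phenylpropyl)amino, an open chain ending in a six-membered aromatic ring that brings a hydrogen-bond donor, gives a 3.4-fold higher number from compound 2 to compound 4 (0.53 log units; beyond the scatter), a modest step that leaves measurable antiproliferative activity in place. The piperazine ring alone does not fix the number either: compound 1 gives 29000 nM with that ring on the same carbon, while compound 4 gives 9430 nM without it, so the outcome at this position depends on the whole group and not simply on the presence of the ring. Nothing in the data shown accounts for the rise from the piperazine amide to the phenylpropylamide.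

The compounds shown leave open whether the length of the chain matters, as a benzylamino or 2-phenylethylamino group on the carbonyl carbon would show, and whether the amide hydrogen matters, as the N-methyl form of the (3-phenylpropyl)amino group would show. They also leave open whether a dimethylamino group at the end of the propyl chain, in place of the phenyl ring, would bring the number back towards that of compound 2.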